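Replacing Cyclopropyl by Benzyl on the Amine Nitrogen

This account rests on a few compounds, and the source may have more. Where it says the series, first, only, none or still open, it means among the compounds named here.

Measured compounds:
Compound 1, `O=C1C(NC2CC2)=CC(=O)c2c1nc1n2[C@H]2OC[C@@H](O)[C@H]2OC1`, gives > 16000 nM in a functional assay on HeLa cells (Homo sapiens) for inhibition, read by sulforhodamine B assay; on this read-out higher numbers stand for weaker inhibition and lower numbers for stronger inhibition; this is a limit of the assay, not a number.
Compound 2, `COc1cccc(NC2=CC(=O)c3nc4n(c3C2=O)[C@H]2OC[C@@H](O)[C@H]2OC4)c1`, gives 4280 nM in this assay.
Compound 3, `O=C1C=C(Nc2ccc(C(F)(F)F)cc2)C(=O)c2c1nc1n2[C@H]2OC[C@@H](O)[C@H]2OC1`, gives > 8000 nM in this assay; this too is a limit, not a number.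

Compound 1 thus stands at the limit of > 16000 nM in this assay, at which 1 of the 3 values shown sits, so only a floor is known for it, and the other compound at a floor sits at the limit of > 8000 nM in this assay, at which 1 of the 3 values shown sits. Compound 4, `O=C1C(NCc2ccccc2)=CC(=O)c2c1nc1n2[C@H]2OC[C@@H](O)[C@H]2OC1`, differs from compound 1 by benzyl in place of cyclopropyl on an amine nitrogen. Within the data shown here, the only measured step, an at least 1.8-fold higher number from compound 2 to compound 3 (0.27 log units; that floor lies within the scatter), exchanges one group carrying an aromatic ring for another on an amine nitrogen and does not bear directly on the present change; it only shows that compound 2, carrying an aromatic ring on that nitrogen, reaches a measurable number in this assay, while compound 3 does not. Compound 4 also brings an aromatic ring, but because compound 1 sits at the limit of > 16000 nM in this assay, at which 1 of the 3 values shown sits, the size of the step cannot be fixed. Compound 4 is expected to give about 10000 nM, within 3000 nM to 30000 nM. The expected step is therefore an at least 1.6-fold lower number from compound 1 to compound 4 (0.20 log units; that floor lies within the scatter), with a fair chance that only a limit is reported again.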

Compound 4, half-maximal inhibitory concentration: 11000 nM
Compound 4: middle estimate off by 1.1-fold (0.04 log units), on the low side; the measured number falls inside the stated range.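

In this assay compound 4 gives 11000 nM, a true number, so this amine nitrogen can carry benzyl and still yield a value the assay can read. Compound 1 gives > 16000 nM, which is a limit of the assay and not a number. The change from cyclopropyl to benzyl is an at least 1.4-fold lower number from compound 1 to compound 4 (0.16 log units; that floor lies within the scatter), and its true size stays unknown, since only a floor is known for compound 1: the limit of > 16000 nM in this assay, at which 1 of the 4 values shown sits.

Still open, on these data alone, is whether the aromatic ring of benzyl matters or whether any larger group would serve as well, a question that cyclohexylmethyl or a longer alkyl chain on the same nitrogen could settle. Also open, as far as these compounds go, is whether an amine or a carboxylic acid on the benzyl ring would move the number, and in which direction.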